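Swapping one amine arm for an oxane ring

The compounds below may be only part of what the source reports. "The series", "measured", "known", "first", "only" and "open" are said of these compounds alone.

Measured compounds:
Compound 1, `CCCN(CCC)c1ccc(C)c2nc(Oc3c(OC)cc(COC)cc3OC)c(C)cc12`; in an assay on HEK293 cells for displacement of a labelled ligand from corticotropin-releasing factor receptor 1 (Homo sapiens), with a stated time of 2 h (on this read-out lower numbers stand for stronger inhibition and higher numbers for weaker inhibition), compound 1 sits at the limit > 1000 nM, which is a limit of the assay and not a number.
Compound 2, `COCc1cc(OC)c(-c2nc3c(C)ccc(N(C)C)c3cc2C)c(OC)c1`; in this assay compound 2 gives 212 nM.
Compound 3, `COCc1cc(OC)c(-c2nc3c(C)ccc(N(CC4CC4)CC4CC4)c3cc2C)c(OC)c1`; in this assay compound 3 gives 88 nM.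

Compound 3 holds the lowest of the two numbers shown, and its nearest neighbour is compound 2, from which it is separated by a 2.4-fold lower number from compound 2 to compound 3 (0.38 log units; beyond the scatter). Compound 4, `COCc1cc(OC)c(-c2nc3c(C)ccc(N(CC4CC4)C4CCOCC4)c3cc2C)c(OC)c1`, differs from compound 3 in one place: oxan-4-yl in place of cyclopropylmethyl on a nitrogen on an aromatic ring. Within the data shown here, only one measured step concerns this nitrogen, and it changed both arms at once, so the effect of trading a single cyclopropylmethyl for an oxan-4-yl has no direct precedent here. The step from compound 2 to compound 3 was modest, and a comparable size is the most that can be expected; the direction cannot be read from the shown compounds, so a change no larger than the scatter, perhaps a slightly higher number, is expected in this assay, that is a 1.4-fold higher number from compound 3 to compound 4 (0.13 log units; within the scatter). Compound 4 is therefore estimated at 120 nM, between 40 nM and 350 nM.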

Compound 4, half-maximal inhibitory concentration: 246 nM
Compound 4: the middle estimate sits 2.1-fold (0.31 log units) below what was measured; measured number inside the range.
By their numbers in this assay, from the lowest: compound 3; then compounds 2 and 4 (each within the scatter of the next). At a limit, above all of these: compound 1.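

In this assay, changing only one arm on this nitrogen is enough to move the number: oxan-4-yl in place of cyclopropylmethyl gives a 2.8-fold higher number from compound 3 to compound 4 (0.45 log units; beyond the scatter), whereas the earlier step had changed both arms together. Measured against dimethylamino, the mixed (cyclopropylmethyl)(oxan-4-yl)amino group gives a 1.2-fold higher number from compound 2 to compound 4 (0.06 log units; within the scatter), which lies within the scatter, so one cyclopropylmethyl arm paired with oxan-4-yl does not keep the gain seen with two cyclopropylmethyl arms. Nothing among the measurements shown explains why this swap raises the number.

The compounds shown leave open whether the higher number goes with the oxygen of the oxan-4-yl ring or with the six-membered ring itself. A cyclohexyl arm on the same nitrogen would separate these two readings, and a simple propyl arm would show how much a ring matters at all.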